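The source may hold more compounds than are shown below. What is called first, only, known or untested is meant among the compounds shown, and "the series" means these compounds.

Measured compounds:
compound 1, `COc1cc(-c2nn(-c3cccc(NC(=O)c4cccc(C(F)(F)F)c4)c3)cc2-c2ccncc2)ccc1Cl`: 2980 nM
compound 2, `COc1cc(-c2nn(-c3cccc(NC(=O)Nc4ccc(Cl)c(Cl)c4)c3)cc2-c2ccncc2)ccc1Cl`: 2270 nM
compound 3, `COc1cc(-c2nn(-c3cccc(NC(=O)c4ccc(Cl)c(C(F)(F)F)c4)c3)cc2-c2ccncc2)ccc1Cl`: 19800 nM

In a functional assay on OVCAR-3 cells (Homo sapiens) for inhibition, read by sulforhodamine B assay, with a stated time of 48 h (a lower number here means a stronger inhibitor of growth, a higher number a weaker inhibitor of growth), compound 3 gives the highest of the three numbers, and both of its gaps to the others lie beyond the scatter: a 6.6-fold higher number from compound 1 to compound 3 (0.82 log units; beyond the scatter) and an 8.7-fold higher number from compound 2 to compound 3 (0.94 log units; beyond the scatter). Compound 3 is therefore the weakest growth inhibitor of the three measured compounds, while compound 1 and compound 2 stand within the scatter of each other, as a 1.3-fold lower number from compound 1 to compound 2 (0.12 log units; within the scatter) shows.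

Compound 4, `COc1cc(-c2nn(-c3cccc(NC(=O)c4ccccc4)c3)cc2-c2ccncc2)ccc1Cl`, has not been measured. It differs from compound 3 by phenyl in place of 4-chloro-3-(trifluoromethyl)phenyl on a carbonyl carbon. The step from compound 3 to compound 1 bears on this directly, since it also strips a chloro from the same aromatic ring and gives a 6.6-fold higher number from compound 1 to compound 3 (0.82 log units; beyond the scatter) read in reverse. Among the measured compounds shown here, compound 4 goes one substituent further, removing the trifluoromethyl as well, for which no measured pair exists. Compound 4 is thus expected to come down from compound 3 by about the size of that step, estimated as a 5.0-fold lower number from compound 3 to compound 4 (0.69 log units; beyond the scatter), landing near compound 1. The estimated value for compound 4 in this assay is 4000 nM, with a range from 1500 nM to 12000 nM.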

Compound 4, concentration for total growth inhibition: 10900 nM
Compound 4: the middle estimate sits 2.7-fold (0.44 log units) below what was measured; low and high end bracket the measured number.
By their numbers in this assay, from the lowest: compounds 2 and 1 (each within the scatter of the next); then compounds 4 and 3 (each within the scatter of the next).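

In this assay, the groups on the ring at this carbonyl carbon do not add up simply: removing chloro and trifluoromethyl together gives a 1.8-fold lower number from compound 3 to compound 4 (0.26 log units; within the scatter), whereas removing trifluoromethyl alone gives a 3.7-fold higher number from compound 1 to compound 4 (0.56 log units; beyond the scatter). Among the compounds shown here, compound 1, with trifluoromethyl as the only group on that ring, therefore stands apart from both neighbours, and the plain phenyl does not share its number; replacing the (3,4-dichlorophenyl)amino group with phenyl gives a 4.8-fold higher number from compound 2 to compound 4 (0.68 log units; beyond the scatter). Nothing available on these compounds accounts for these differences.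

On these data alone, whether a lone chloro on the phenyl ring would sit with compound 1 or with compound 4 remains open. So does how an amine or a carboxylic acid on that ring would read in this assay.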